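From compound 3 to compound 4: a trifluoromethoxy exchange

The source may hold more compounds than are shown below. What is called first, only, known or untested is meant among the compounds shown, and "the series" means these compounds.

Compound 1 `CC(O)(CSc1ccc(S(F)(F)(F)(F)F)cc1)C(=O)Nc1ccc(C#N)cc1C(F)(F)F` gives 17700 nM
Compound 2 `CC(O)(CSc1ccccc1OC(F)(F)F)C(=O)Nc1cccc(S(F)(F)(F)(F)F)c1` gives 17500 nM
Compound 3 `CC(O)(COc1cccc(S(F)(F)(F)(F)F)c1)C(=O)Nc1ccc(S(F)(F)(F)(F)F)cc1` gives 29600 nM

All three values come from a functional assay on DU-145 cells (Homo sapiens) for antiproliferative activity, read by propidium iodide staining, with a stated time of 96 h (a higher number here means a weaker inhibitor, a lower number a stronger inhibitor), and lie within the usual scatter of one another. Compound 3, at 29600 nM in that read-out, therefore stands level with both compound 1 and compound 2 on these numbers. No two of the three differ in one place only, so the data hold no direct measure of a single exchange.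

Compound 4 `CC(O)(COc1cccc(OC(F)(F)F)c1)C(=O)Nc1ccc(S(F)(F)(F)(F)F)cc1` differs from compound 3 by one exchange (a group of 5 heavy atoms (1 carbon, 1 oxygen, 3 fluorine; no ring) in place of a group of 6 heavy atoms (5 fluorine, 1 sulfur; no ring), on an aromatic carbon). Trifluoromethoxy stands in place of a group of 6 heavy atoms (5 fluorine, 1 sulfur; no ring), on an aromatic carbon of a six-membered aromatic ring of carbon only, meta to a large group. Compound 2 also carries trifluoromethoxy, and at 17500 nM it sits in the same band as the others. With so little evidence, no step beyond the scatter is expected in this assay, and no direction can be argued with any confidence. The expected step is a 1.4-fold lower number from compound 3 to compound 4 (0.15 log units; within the scatter) on this estimate. Compound 4 is therefore expected at 21000 nM in this assay (estimated range 9000 nM to 45000 nM).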

Compound 4, half-maximal inhibitory concentration: 18400 nM
The estimate for compound 4 lay 1.1-fold (0.06 log units) above the measured number; low and high end bracket the measured number.
By their numbers in this assay, from the lowest: compounds 2, 1, 4 and 3 (each within the scatter of the next).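

In this assay, putting trifluoromethoxy in place of the group of 6 heavy atoms (5 fluorine, 1 sulfur; no ring), on an aromatic carbon of a six-membered aromatic ring of carbon only, meta to a large group, gives a 1.6-fold lower number from compound 3 to compound 4 (0.21 log units; within the scatter). Among these compounds, this is the first direct reading of a single exchange, since none of the earlier compounds differed in one place only, and it shows that this assay does not separate these two groups at this position, even though the entering group counts 1 hydrogen-bond acceptor and the leaving group none. Nothing available explains why the two groups read alike here.

The compounds shown leave open whether a different kind of group at this position, such as an amine, a carboxylic acid or a longer chain, would move the number beyond the scatter. They also leave open whether the same exchange would read alike at another place on the shared core, where the group of 6 heavy atoms also stands in compound 4.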